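The compounds below may be only part of what the source reports. "The series", "measured", "known", "first", "only" and "open" are said of these compounds alone.

In a functional assay on cells (T-cell, Mus musculus, strain BALB/c) for inhibition, read by MTT assay, with stated times of 24 h and 72 h (a higher number here means a weaker inhibitor, a lower number a stronger inhibitor), compound 1 `COc1cc(-c2nnc(SCc3ccc(C)cc3)o2)ccc1O` gives 6210 nM, compound 2 `COc1cc(-c2nnc(SCc3ccccc3C)o2)ccc1O` gives 8420 nM, and compound 3 `COc1cc(-c2nnc(SCc3ccccc3)o2)ccc1O` gives 1250 nM, the lowest of the three numbers. Compound 4 `COc1cccc(CSc2nnc(-c3ccc(O)c(OC)c3)o2)c1` carries one change from compound 3: methoxy in place of hydrogen on an aromatic carbon. Going by the values given here, no measured step involves methoxy, so the nearest guides are the methyl steps. Hydrogen in place of methyl on an aromatic carbon gave a 5.0-fold lower number from compound 1 to compound 3 (0.70 log units; beyond the scatter) and a 6.7-fold lower number from compound 2 to compound 3 (0.83 log units; beyond the scatter), both modest and beyond the scatter, while 2-methylphenyl in place of 4-methylphenyl gave a 1.4-fold higher number from compound 1 to compound 2 (0.13 log units; within the scatter), within the scatter. Adding a group to the phenyl of compound 3 is thus expected to give a similar or smaller step upward, a 3.2-fold higher number from compound 3 to compound 4 (0.51 log units; beyond the scatter). Compound 4 is estimated at 4000 nM, with an expected range of 1300 nM to 12000 nM.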

Compound 4, half-maximal inhibitory concentration: 7410 nM
Estimate against measurement, compound 4: 1.9-fold (0.27 log units) below, within the range that was stated.
By their numbers in this assay, from the lowest: compound 3; then compounds 1, 4 and 2 (each within the scatter of the next).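

In this assay the change from phenyl to 3-methoxyphenyl gives a 5.9-fold higher number from compound 3 to compound 4 (0.77 log units; beyond the scatter) and so shows that a methyl is not the only added group that goes with a weaker inhibitor: among these four compounds, all three with a group on this phenyl have higher numbers than compound 3. Which added group it is, and where it sits, makes no readable difference here, with a 1.1-fold lower number from compound 2 to compound 4 (0.06 log units; within the scatter) and a 1.2-fold higher number from compound 1 to compound 4 (0.08 log units; within the scatter) as the steps among them.

From the compounds shown here alone, whether an amine or a carboxylic acid on this phenyl would also raise the number stays open. No measurement at hand explains these steps.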